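Sulfanyl for oxygen link in a diaminoquinoxaline pair

This account rests on a few compounds, and the source may have more. Where it says the series, first, only, none or still open, it means among the compounds named here.

Measured in a functional assay on DU-145 cells (Homo sapiens) for inhibition, read by sulforhodamine B assay, with a stated time of 48 h; on this read-out higher numbers stand for weaker inhibition of growth and lower numbers for stronger inhibition of growth:
- compound 1 `Nc1cc(N)c2nc(-c3ccccc3)c(Oc3ccc(Cl)c(Cl)c3)nc2c1` gives only a limit of the assay, < 100000 nM
- compound 2 `COc1ccc(CNc2nc3cc(N)cc(N)c3nc2-c2ccccc2)cc1OC` gives 87100 nM

Compound 1 stands at a limit in this assay and carries no number of its own; the evidence for it is the limit of < 100000 nM in this assay, at which 1 of the 2 values shown sits. Compound 2 sits close to that same limit, at the weak end of growth inhibition. For the measured compounds named here, no step between two measured compounds is available here, so nothing measured tells how much the linking atom matters.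

Compound 3 `Nc1cc(N)c2nc(-c3ccccc3)c(Sc3ccc(Cl)c(Cl)c3)nc2c1` differs from compound 1 in one place: (3,4-dichlorophenyl)sulfanyl in place of 3,4-dichlorophenoxy on an aromatic carbon. The exchange keeps the same heavy-atom count and the same single hydrogen-bond acceptor, so it is expected to move little: the step that the limit leaves unreadable from compound 1 to compound 3 is expected to stay within the usual scatter, in no clear direction. Compound 3 is therefore estimated at 70000 nM in this assay, with a likely range from 20000 nM to 200000 nM, and a fair chance that it too is reported only as a limit.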

Compound 3, concentration for total growth inhibition: 3800 nM
For compound 3 the middle estimate is 18-fold (1.27 log units) above the measured one; the whole stated range lies above it.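

No step from compound 1 to compound 3 can be sized, as compound 1 carries only a limit and compound 3 a number: the limit of < 100000 nM in this assay, at which 1 of the 3 values shown sits.

Left open is how large the difference between the 3,4-dichlorophenoxy and (3,4-dichlorophenyl)sulfanyl groups really is, and whether it would hold with other groups on the shared core.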